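This account rests on a few compounds, and the source may have more. Where it says the series, first, only, none or still open, it means among the compounds named here.

Three compounds have been measured in a functional assay on PC-3 cells (Homo sapiens) for inhibition, read by MTT assay, with a stated time of 72 h; a higher number here means a weaker inhibitor, a lower number a stronger inhibitor:

compound 1, `C=CC(=O)Nc1cccc(NC(=O)CSc2nc(Nc3ccccc3Cl)c3ccccc3n2)c1`: 14400 nM
compound 2, `C=CC(=O)Nc1cccc(NC(=O)CSc2nc(Nc3ccccc3C)c3ccccc3n2)c1`: 23200 nM
compound 3, `C=CC(=O)Nc1cccc(NC(=O)CSc2nc(Nc3cccc(Cl)c3)c3ccccc3n2)c1`: 12300 nM

Compound 3 gives the lowest of the three numbers, but its separation from the others is small: the step from compound 1 to compound 3 is a 1.2-fold lower number from compound 1 to compound 3 (0.07 log units; within the scatter), and the step from compound 2 to compound 3 is a 1.9-fold lower number from compound 2 to compound 3 (0.28 log units; within the scatter), both within the scatter. The three compounds therefore cannot be ranked against each other in this assay on these numbers.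

Compound 4, `C=CC(=O)Nc1cccc(NC(=O)CSc2nc(Nc3cccc(Br)c3)c3ccccc3n2)c1`, differs from compound 3 in one place: bromo in place of chloro on an aromatic carbon. For the measured compounds named here, no measured step exchanges one halogen for another. Going by the values given here, the only measured change at a single aromatic carbon on that phenyl ring is the step from compound 1 to compound 2, a 1.6-fold higher number from compound 1 to compound 2 (0.21 log units; within the scatter), where methyl replaced chloro and the number stayed within the scatter. Among the compounds with values here, all three measured steps are within the scatter, so there is no precedent here for a change of this kind moving the number beyond it.

Compound 4 is therefore expected to give a number close to that of compound 3, with the expected step being a 1.0-fold lower number from compound 3 to compound 4 (0.01 log units; within the scatter). The estimate for compound 4 in this assay is 12000 nM, with a range from 6000 nM to 25000 nM.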

Compound 4, half-maximal inhibitory concentration: 15000 nM
Estimate against measurement, compound 4: 1.3-fold (0.10 log units) below, and the stated range covers the measured number.
By their numbers in this assay, from the lowest: compounds 3, 1, 4 and 2 (each within the scatter of the next).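

In this assay, for the compounds shown here, the exchange of one halogen for another on this aromatic carbon, meta to a large group, is seen for the first time, and it gives a 1.2-fold higher number from compound 3 to compound 4 (0.09 log units; within the scatter) without taking the number beyond the scatter. The 3-bromophenyl group likewise stays close to the other groups on this nitrogen in this assay: the step from the 2-methylphenyl group is a 1.5-fold lower number from compound 2 to compound 4 (0.19 log units; within the scatter) and the step from the 2-chlorophenyl group is a 1.0-fold higher number from compound 1 to compound 4 (0.02 log units; within the scatter) so across the four compounds, no change on this phenyl ring separates one from another. Nothing measured here accounts for these small steps, so no cause can be offered for them.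

The compounds shown leave open whether a group of another kind on this phenyl ring, such as an amine or a carboxylic acid, would move the number beyond the scatter. They also leave open whether a change away from this ring, such as a longer chain on the shared core, would do so.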